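Replacing fluoro with hydroxy in compound 3

The compounds below may be only part of what the source reports. "The series", "measured", "known", "first", "only" and "open" are said of these compounds alone.

Measured in a functional assay on KB cells (Homo sapiens) for antiproliferative activity, with a stated time of 72 h (on this read-out lower numbers stand for stronger inhibition and higher numbers for weaker inhibition), so far:
- compound 1 `C=C1C=CC(=O)[C@@H]2[C@H](Cc3ccc(OCOC)c(F)c3)CC[C@H]12` at 76.6 nM
- compound 2 `C=C1C=CC(=O)[C@@H]2[C@H](Cc3ccc(F)c(F)c3)CC[C@H]12` at 478 nM
- compound 3 `C=C1C=CC(=O)[C@@H]2[C@H](Cc3ccc(OC)c(F)c3)CC[C@H]12` at 2.77 nM

Compound 3 has the lowest number of the three, clear of both others. Compound 4 `C=C1C=CC(=O)[C@@H]2[C@H](Cc3ccc(OC)c(O)c3)CC[C@H]12` carries hydroxy in place of fluoro on an aromatic carbon. Among the compounds with values here, all three measured compounds keep that fluoro, so no measured step tests this change directly. The nearest guides are a 170-fold lower number from compound 2 to compound 3 (2.24 log units; beyond the scatter) and a 28-fold lower number from compound 1 to compound 3 (1.44 log units; beyond the scatter) (both large), and a 6.2-fold higher number from compound 1 to compound 2 (0.80 log units; beyond the scatter) (modest). These show that small changes around the aromatic ring can move the number far, though none falls at this carbon. A modest weakening in this assay is therefore expected, estimated as a 3.2-fold higher number from compound 3 to compound 4 (0.51 log units; beyond the scatter) and uncertain in size. For compound 4 the estimated value is 9 nM (range 2 nM to 40 nM).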

Compound 4, half-maximal inhibitory concentration: 4.94 nM
The estimate for compound 4 lay 1.8-fold (0.26 log units) above the measured number; low and high end bracket the measured number.
By their numbers in this assay, from the lowest: compounds 3 and 4 (each within the scatter of the next); then compound 1; then compound 2.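

In this assay, hydroxy in place of fluoro on this aromatic carbon, ortho to a methoxy group, gives a 1.8-fold higher number from compound 3 to compound 4 (0.25 log units; within the scatter), so the two groups cannot be told apart here. Within the data shown here, this is the first change at this carbon, and it shows none of the large movement seen at the other ring carbon, where a 170-fold lower number from compound 2 to compound 3 (2.24 log units; beyond the scatter). No supporting measurement bears on this result. From the compounds shown here alone, whether an amine or a carboxylic acid on this carbon would stay as close to compound 3 remains open, as does whether hydroxy would hold with a longer chain in place of the methoxy group.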